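Adding a Methyl to the Chloropyridine of Compound 2

A few compounds are considered here, and "the series" means these few. Any claim that something is new, unique, unknown or untested is made for them only; others in the source may bear on it.

Compound 2 `CC(C)N(CCN(C(=O)N(C)C)c1cccc(Cl)n1)C(C)C` gives 78% in a functional assay on the whole organism (stomach) for inhibition, with Canis familiaris (Canis lupus familiaris) as the target, at a dose of 20 mg/kg by the oral route (on this read-out lower numbers stand for a weaker effect and higher numbers for a stronger effect at the one dose given), the lowest of the two numbers shown; compound 1 `Cc1ccnc(N(CCN(C(C)C)C(C)C)C(=O)N(C)C)c1` gives 95%. The step of a number 17 percentage points lower from compound 1 to compound 2 (beyond the scatter) is the only measured one, and it swaps one ring substituent for another rather than adding a second, so it bears only loosely on compound 3 `Cc1cc(Cl)nc(N(CCN(C(C)C)C(C)C)C(=O)N(C)C)c1`, which differs from compound 2 by methyl in place of hydrogen on an aromatic carbon. For the measured compounds named here, no measured step adds methyl to a ring that already carries chloro. For compound 3 a step within the scatter is therefore expected, a number 7 percentage points higher from compound 2 to compound 3 (within the scatter). Compound 3 is estimated at 85%, with a range from 65% to 98%.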

Compound 3, a percentage reported as inhibition, in the whole organism at one dose (the size of the read-out at that dose, not a potency): 71%
Compound 3: the middle estimate sits 14 percentage points above what was measured, within the range that was stated.
By their numbers in this assay, from the lowest: compounds 3 and 2 (each within the scatter of the next); then compound 1.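

On the ring carbon opposite the ring nitrogen, methyl in place of hydrogen gives a number 7 percentage points lower from compound 2 to compound 3 (within the scatter) in this assay, so a methyl group there, on a ring already carrying chloro, does not separate the two compounds. Chloro in place of hydrogen, on a ring that keeps this methyl, gives a number 24 percentage points lower from compound 1 to compound 3 (beyond the scatter) and thus costs effect without any swap of substituents. Nothing available explains either step. From the compounds shown here alone, whether an amine or a longer chain on this ring carbon would separate from methyl stays open, as does whether methyl matters on a ring without chloro.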